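This account rests on a few compounds, and the source may have more. Where it says the series, first, only, none or still open, it means among the compounds named here.

Measured in a functional assay on PC-3 cells (Homo sapiens) for cytotoxicity, read by MTT assay, with a stated time of 72 h; a higher number here means a weaker inhibitor, a lower number a stronger inhibitor:
- compound 1 `O=C(N/N=C/c1cccc(Br)c1)Nc1cc2c(Nc3ccc(F)c(Cl)c3)ncnc2cc1O[C@H]1CCOC1`: 15500 nM
- compound 2 `COc1ccc(/C=N/NC(=O)Nc2cc3c(Nc4ccc(F)c(Cl)c4)ncnc3cc2O[C@H]2CCOC2)c(OC)c1OC`: 25600 nM
- compound 3 `O=C(N/N=C/c1ccc(O)cc1O)Nc1cc2c(Nc3ccc(F)c(Cl)c3)ncnc2cc1O[C@H]1CCOC1`: 7540 nM

Compound 3 holds the lowest of these numbers, reached by a 2.1-fold lower number from compound 1 to compound 3 (0.31 log units; beyond the scatter) and by a 3.4-fold lower number from compound 2 to compound 3 (0.53 log units; beyond the scatter). In compound 4 `CCN(CC)c1ccc(/C=N/NC(=O)Nc2cc3c(Nc4ccc(F)c(Cl)c4)ncnc3cc2O[C@H]2CCOC2)c(O)c1` diethylamino stands in place of hydroxy on an aromatic carbon, turning 2,4-dihydroxyphenyl into 4-(diethylamino)-2-hydroxyphenyl (diethylamino in place of hydroxy on an aromatic carbon). For the measured compounds named here, no measured step makes this exchange. The closest evidence is the other changes to this phenyl group, which stayed small: a 1.7-fold higher number from compound 1 to compound 2 (0.22 log units; within the scatter), and the two steps to compound 3 were modest. A small rise, not clearly beyond the scatter, is expected in this assay, namely a 1.6-fold higher number from compound 3 to compound 4 (0.20 log units; within the scatter). For compound 4 the estimate is 12000 nM, with an expected range of 5000 nM to 28000 nM.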

Compound 4, half-maximal inhibitory concentration: 4590 nM
Beside the measured number, compound 4's estimate is 2.6-fold (0.42 log units) above it, and the stated range ends above it.
By their numbers in this assay, from the lowest: compounds 4 and 3 (each within the scatter of the next); then compounds 1 and 2 (each within the scatter of the next).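

In this assay, this position, para to a large group, takes diethylamino, with 5 heavy atoms and 0 hydrogen-bond donors, in place of hydroxy with only a 1.6-fold lower number from compound 3 to compound 4 (0.22 log units; within the scatter). Compound 4 also stands clear of the other two aryl variants, with a 5.6-fold lower number from compound 2 to compound 4 (0.75 log units; beyond the scatter) and a 3.4-fold lower number from compound 1 to compound 4 (0.53 log units; beyond the scatter). No measurement offered here explains this tolerance. The compounds shown leave open how a smaller amine such as dimethylamino, or a ring amine such as morpholine, would read at this position, and what the remaining hydroxy group contributes.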